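Allyloxy for dichlorophenylsulfanyl on two related purine-like cores

The compounds below may be only part of what the source reports. "The series", "measured", "known", "first", "only" and "open" are said of these compounds alone.

Compound 1 `Clc1ccc(Sc2ncnc3c2ncn3C2COc3ccccc3CO2)c(Cl)c1`: 12000 nM
Compound 2 `C=CCOc1ncnc2c1ncn2C1COc2ccccc2CO1`: 5040 nM
Compound 3 `Clc1ccc(Sc2ncnc3ncn(C4COc5ccccc5CO4)c23)c(Cl)c1`: 8400 nM

Three compounds were measured in a functional assay on MCF7 cells (Homo sapiens) for antiproliferative activity, read by sulforhodamine B assay, with a stated time of 3 days; a lower number here means a stronger inhibitor, a higher number a weaker inhibitor. Compound 1 gives 12000 nM in this assay, and compound 2, which differs from it in a single place, gives 5040 nM. The change between them, (allyloxy in place of (2,4-dichlorophenyl)sulfanyl on an aromatic carbon), produced the step of a 2.4-fold lower number from compound 1 to compound 2 (0.38 log units; beyond the scatter). Compound 3 carries the same atoms as compound 1, joined differently; the difference between the two cores is not broken down here. In this assay compound 3 gives 8400 nM, which lies within the usual scatter of the values of compound 1 and of compound 2.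

Compound 4 `C=CCOc1ncnc2ncn(C3COc4ccccc4CO3)c12` has not been measured. It relates to compound 3 as compound 2 relates to compound 1: the change is allyloxy in place of (2,4-dichlorophenyl)sulfanyl on an aromatic carbon, and since the surroundings of the place are the same in both pairs, it is the same change. Within the data shown here, the step from compound 3 to compound 4 is expected to be a 2.4-fold lower number from compound 3 to compound 4 (0.38 log units; beyond the scatter), resting on the one measured instance, the step of a 2.4-fold lower number from compound 1 to compound 2 (0.38 log units; beyond the scatter). Accordingly, compound 4 is estimated to give 3500 nM in this assay, with a plausible range from 1500 nM to 8000 nM.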

Compound 4, half-maximal inhibitory concentration: 20900 nM
Compound 4: middle estimate off by 6.0-fold (0.78 log units), on the low side, outside the stated range (above it).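

In this assay, putting allyloxy in place of (2,4-dichlorophenyl)sulfanyl on the core of compound 3 did not repeat what the same change did on the core of compound 1; it gave a 2.5-fold higher number from compound 3 to compound 4 (0.40 log units; beyond the scatter). Set side by side, the two instances run in opposite directions, and the gap between them is larger than repeated measurement would account for: the same change on two cores in this assay, a 2.4-fold lower number (0.38 log units; beyond the scatter) from compound 1 to compound 2 and a 2.5-fold higher number (0.40 log units; beyond the scatter) from compound 3 to compound 4, 5.9-fold (0.77 log units) apart, beyond the scatter of two such steps. In this series, then, the step measured on one core cannot be carried to the other, in direction or in size, although two pairs do not show why the cores differ or how the change would behave on any further core.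

On these data alone, only these two groups appear at this place, so it remains open whether an amine, a methoxy group or a longer alkoxy chain would follow the trend on both cores. Also open is whether opposite steps would return with other pairs of groups on these two cores, or belong to allyloxy and (2,4-dichlorophenyl)sulfanyl alone.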